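The compounds below may be only part of what the source reports. "The series", "measured", "known", "first", "only" and "open" are said of these compounds alone.

Measured so far:
- Compound 1, `O=C(/C=C/c1ccc2c(c1)C(=O)N(Cc1ccc(-c3ccccc3)cc1)C2)NO`: 750 nM
- Compound 2, `O=C(/C=C/c1ccc2c(c1)C(=O)N(Cc1ccc(-c3cccnc3)cc1)C2)NO`: 280 nM

Both compounds were tested in an assay on isolated protein for inhibition of protein deacetylase HDAC6 (Homo sapiens); on this read-out higher numbers stand for weaker inhibition and lower numbers for stronger inhibition. Compound 2 gives the lower of the two numbers, and the step from compound 1 to compound 2 was a 2.7-fold lower number from compound 1 to compound 2 (0.43 log units; beyond the scatter), a modest move in the direction of stronger inhibition. Among the measured compounds shown here, the only structural change in that step was the exchange of phenyl for pyridin-3-yl on an aromatic carbon.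

Compound 3, `O=C(/C=C/c1ccc2c(c1)C(=O)N(Cc1ccc(-c3ccncc3)cc1)C2)NO`, has not yet been measured in this assay. It differs from compound 2 only in that (pyridin-4-yl in place of pyridin-3-yl on an aromatic carbon). So the ring nitrogen stays but sits elsewhere in the same six-membered ring.

For the measured compounds named here, the single measured step bears on this only indirectly: it shows that putting a nitrogen into that ring gave a modest gain, but says nothing about which placing of it matters. Moving the nitrogen from one ring position to another is a smaller change than adding it, so the step from compound 2 to compound 3 is expected to stay within the scatter, a 1.1-fold higher number from compound 2 to compound 3 (0.03 log units; within the scatter). Compound 3 is therefore estimated at 300 nM, with a range of 120 nM to 750 nM.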

Compound 3, half-maximal inhibitory concentration: 15000 nM
For compound 3 the middle estimate is 50-fold (1.70 log units) below the measured one, and the stated range ends below it.
By their numbers in this assay, from the lowest: compound 2; then compound 1; then compound 3.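

In this assay, where the ring nitrogen sits matters far more at this position than whether it is there: moving it gives a 54-fold higher number from compound 2 to compound 3 (1.73 log units; beyond the scatter) even though pyridin-3-yl and pyridin-4-yl have the same atoms and the same counts of hydrogen-bond donors and acceptors. The earlier gain, a 2.7-fold lower number from compound 1 to compound 2 (0.43 log units; beyond the scatter), therefore cannot be read as a general benefit of a ring nitrogen, since pyridin-4-yl goes the other way with a 20-fold higher number from compound 1 to compound 3 (1.30 log units; beyond the scatter) and leaves the phenyl compound between the two pyridines. No measurement at hand explains why these two placements of one atom differ so sharply.

The three compounds leave open how the remaining placement, pyridin-2-yl, or a ring with a second nitrogen, such as pyrimidin-5-yl, would fall on this scale. They also leave open whether a phenyl ring carrying a methoxy group or an amine at the spot that holds the pyridin-4-yl nitrogen would show the same large loss, which would tell whether the nitrogen itself or simply any change at that spot goes with it.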